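Replacing an aryl group on an aromatic nitrogen with tert-butyl

The source may report more compounds than this note shows. Statements on the series, on what has been measured and on what is new or still open speak of the compounds shown alone.

Of the compounds shown here, three built on one shared core have so far been measured in an assay on isolated protein for inhibition of STE20-like serine/threonine-protein kinase (Homo sapiens), read by thermal shift assay, tested at 10 uM; on this read-out lower numbers stand for weaker stabilisation of the target and higher numbers for stronger stabilisation of the target against heat. Compound 1 `Cc1ccc(-n2nc(C(C)(C)C)cc2NC(=O)Nc2cc(C(F)(F)F)cc(C(F)(F)F)c2)cc1` gives 0 degrees C. Compound 2 `Cn1nc(C(C)(C)C)cc1NC(=O)Nc1cc(C(F)(F)F)cc(C(F)(F)F)c1` carries methyl in place of 4-methylphenyl on an aromatic nitrogen and gives 2.4 degrees C, a change of a number 2.4 degrees C higher from compound 1 to compound 2 (beyond the scatter). Compound 3 `CC(C)(C)c1cc(NC(=O)Nc2cc(C(F)(F)F)cc(C(F)(F)F)c2)n(-c2ccc(F)cc2)n1` gives 0.5 degrees C, which places it second highest of the three numbers: compound 1 lies close, with a number 0.50 degrees C higher from compound 1 to compound 3 (within the scatter), while compound 2 lies farther away, with a number 1.9 degrees C lower from compound 2 to compound 3 (beyond the scatter).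

Compound 4 `CC(C)(C)c1cc(NC(=O)Nc2cc(C(F)(F)F)cc(C(F)(F)F)c2)n(C(C)(C)C)n1` differs from compound 3 by tert-butyl in place of 4-fluorophenyl on an aromatic nitrogen. Going by the values given here, the steps that bear on this are the two in which the group on that same nitrogen was exchanged, a number 2.4 degrees C higher from compound 1 to compound 2 (beyond the scatter) and a number 1.9 degrees C lower from compound 2 to compound 3 (beyond the scatter), both modest and both with the small methyl group giving the higher number. Tert-butyl is not methyl, but it is also not an aromatic ring, so a modest rise in this assay is expected, a number 1.0 degrees C higher from compound 3 to compound 4 (within the scatter). Compound 4 is therefore estimated at 1.5 degrees C, with a range from 0 degrees C to 3 degrees C.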

Compound 4, shift of the target's melting temperature: -0.2 degrees C
Compound 4: the middle estimate sits 1.7 degrees C above what was measured; measured number outside the range, below it.
By their numbers in this assay, from the lowest: compounds 4, 1 and 3 (each within the scatter of the next); then compound 2.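

In this assay, tert-butyl on the aromatic nitrogen does not behave like methyl, with a number 2.6 degrees C lower from compound 2 to compound 4 (beyond the scatter), yet it cannot be told apart from either aryl group, with a number 0.70 degrees C lower from compound 3 to compound 4 (within the scatter) and a number 0.20 degrees C lower from compound 1 to compound 4 (within the scatter). Removing the aromatic ring from this position is therefore not enough on its own to reach the number of compound 2, and among the four groups compared here only methyl stands apart. Nothing available here explains why these groups give these numbers.

From the compounds shown here alone, what ethyl, isopropyl or a short chain ending in an amine would give on this nitrogen remains open, so the point at which the number falls between methyl and tert-butyl is unknown. Going by these compounds, it is also open whether methyl would still stand apart if a cyclopropyl group replaced the other tert-butyl on the core.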